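A few compounds are considered here, and "the series" means these few. Any claim that something is new, unique, unknown or untested is made for them only; others in the source may bear on it.

Working notes on the series

Measured compounds, cytotoxicity on mouse macrophage-like cells:
- compound 1 `Cc1[nH]c2ccc(Br)cc2c(=O)c1Br`: > 31500 nM, a limit of the assay and not a number
- compound 2 `Cc1[nH]c2ccc(Cl)cc2c(=O)c1Br`: 21700 nM
- compound 3 `CCc1c(C)[nH]c2cc(OC)c(Cl)cc2c1=O`: 19000 nM

In an ADME assay on J774 cells (Mus musculus) for cytotoxicity (on this read-out lower numbers stand for an effect already at smaller amounts and higher numbers for an effect only at larger amounts of compound), compound 2 gives 21700 nM. Compound 3 gives 19000 nM, the lower of the two numbers, but the gap to compound 2 lies within the scatter, so no order between them is claimed. Compound 1 reaches only the limit of the assay. Among the measured compounds shown here, the one counted step is an at least 1.4-fold higher number from compound 2 to compound 1 (0.16 log units; that floor lies within the scatter); the change is bromo in place of chloro on an aromatic carbon. That step is known only as a floor because of the limit of > 31500 nM in this assay, at which 1 of the 3 values shown sits.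

The difference between the cores of compound 2 and compound 3 is not broken down here.

Not yet measured is compound 4 `CCc1c(C)[nH]c2cc(OC)c(Br)cc2c1=O`. For the measured compounds named here, it differs from compound 3 by bromo in place of chloro on an aromatic carbon, which is the same kind of change as the one from compound 2 to compound 1; around the place it differs in that the carbon is ortho to a methoxy group. On the strength of the step of an at least 1.4-fold higher number from compound 2 to compound 1 (0.16 log units; that floor lies within the scatter), the step from compound 3 to compound 4 is expected to be a 1.6-fold higher number from compound 3 to compound 4 (0.20 log units; within the scatter), with the floor of the earlier step leaving its true size open. For compound 4 the expected number in this assay is 30000 nM, estimated to lie between 16000 nM and 60000 nM, with a real chance that only a limit is reported.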

Compound 4, half-maximal effective concentration: > 33900 nM
Compound 4: only a limit was reported; the forecaster's own chance of this, stated with the estimate: 45%; at least 1.1-fold (0.05 log units) between middle value and limit.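

In this assay, the change from chloro to bromo on the second core gives an at least 1.7-fold higher number from compound 3 to compound 4 (0.25 log units; that floor lies within the scatter), and set beside the earlier case it reads: the same change on two cores in this assay, an at least 1.4-fold higher number (0.16 log units; that floor lies within the scatter) from compound 2 to compound 1 and an at least 1.7-fold higher number (0.25 log units; that floor lies within the scatter) from compound 3 to compound 4; the limit leaves it open whether they differ Compound 4 gives > 33900 nM, which is a limit of the assay and not a number. What this shows is that the change, carried to a core where the carbon is ortho to a methoxy group, again ends in a limit and gives nothing against the earlier step, but it does not show that the step has the same size on both cores, nor that it exceeds the scatter on either.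

The compounds shown carry only chloro and bromo at this place, which leaves open how an amine or a carboxylic acid there would read on this measure of cytotoxicity, and whether any such group would bring the number back from the limit. Also open, from the compounds shown here alone, are a longer chain in place of the ethyl group of compound 3 and the separate contributions of the parts that distinguish the core of compound 2 from the core of compound 3.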